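Compound 3 and its bromo analogue

This account rests on a few compounds, and the source may have more. Where it says the series, first, only, none or still open, it means among the compounds named here.

Compound 1 `COc1cc(OC)cc(-c2nnc(SCC(=O)c3ccccc3)o2)c1` gives 170 nM
Compound 2 `O=C(CSc1nnc(-c2ccccc2F)o1)c1ccccc1` gives 260 nM
Compound 3 `O=C(CSc1nnc(-c2cccc3ccccc23)o1)c1ccccc1` gives 230 nM

These values come from a functional assay on MCF7 cells (Homo sapiens) for cytotoxicity, read by MTT assay and propidium iodide staining, with a stated time of 24 h; a higher number here means a weaker inhibitor, a lower number a stronger inhibitor. Compound 3 lies within the scatter of both compound 1 and compound 2, so the three cannot be ranked.

Compound 4 `O=C(CSc1nnc(-c2cccc3ccccc23)o1)c1ccc(Br)cc1` is compound 3 with bromo in place of hydrogen on an aromatic carbon, turning phenyl into 4-bromophenyl (bromo in place of hydrogen on an aromatic carbon). Among the measured compounds shown here, no two measured compounds show what such a change does. With all three measured values this close, no step beyond the scatter is expected, in either direction. The estimated change is a 1.2-fold lower number from compound 3 to compound 4 (0.06 log units; within the scatter) and stays within the scatter. Compound 4 is estimated at 200 nM (range 70 nM to 600 nM).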

Compound 4, half-maximal inhibitory concentration: 260 nM
For compound 4 the middle estimate is 1.3-fold (0.11 log units) below the measured one; the measured number falls inside the stated range.
By their numbers in this assay, from the lowest: compounds 1, 3, 2 and 4 (each within the scatter of the next).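

Turning phenyl into 4-bromophenyl gives a 1.1-fold higher number from compound 3 to compound 4 (0.05 log units; within the scatter) in this assay and is the first single change that can be read in this set. It shows that a bromine atom can stand at this position with no step beyond the scatter, although this one pair cannot show a trend. No measurement at hand bears on why the step is this small.

On these data alone, whether an amine or a carboxylic acid at this position would move the number beyond the scatter remains open. So does whether bromo would behave the same way on the core of compound 1.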